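Swapping chloro for methoxy on a cyclopropyl amide

The compounds below may be only part of what the source reports. "The series", "measured", "known", "first", "only" and "open" are said of these compounds alone.

Compound 1 `C#CCNC(=O)/C(C)=C(\C)c1ccc(OC)cc1` gives 400 mg/kg in a toxicity assay on the whole organism (strain Icem-CET (SPF Caw)) for cytotoxicity, with Mus musculus as the target; on this read-out higher numbers stand for an effect only at larger amounts of compound and lower numbers for an effect already at smaller amounts. Compound 2 `C/C(C(=O)NC1CC1)=C(/C)c1ccccc1` gives 250 mg/kg in this assay. For compound 3 `C/C(C(=O)NC1CC1)=C(/C)c1ccc(Cl)cc1` this assay reports only a limit, > 800 mg/kg, not a number. Compounds 1 and 2 differ in two places, so their values are simply set side by side. Going by the values given here, the single measured step, an at least 3.2-fold higher number from compound 2 to compound 3 (0.50 log units; beyond the scatter), ends at that limit (the limit of > 800 mg/kg in this assay, at which 1 of the 3 values shown sits). The change to compound 4 `COc1ccc(/C(C)=C(\C)C(=O)NC2CC2)cc1` is methoxy in place of chloro on an aromatic carbon. Among the compounds with values here, no measured step covers a methoxy replacing a chloro; compound 1, which carries a methoxy, gives 400 mg/kg. For compound 4 the expected step is an at least 1.7-fold lower number from compound 3 to compound 4 (0.24 log units; that floor lies within the scatter), a move down from the limit. Compound 4 is estimated at 450 mg/kg, between 200 mg/kg and 900 mg/kg.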

Compound 4, dose for half-maximal effect: 300 mg/kg
The estimate for compound 4 lay 1.5-fold (0.18 log units) above the measured number; low and high end bracket the measured number.
By their numbers in this assay, from the lowest: compounds 2, 4 and 1 (each within the scatter of the next). At a limit, above all of these: compound 3.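

In this assay, methoxy in place of hydrogen on the aromatic carbon gives a 1.2-fold higher number from compound 2 to compound 4 (0.08 log units; within the scatter), so unlike chloro it leaves the two compounds indistinguishable. Methoxy in place of chloro gives an at least 2.6-fold lower number from compound 3 to compound 4 (0.42 log units; beyond the scatter), while cyclopropyl in place of propargyl on the amide-type nitrogen, with methoxy kept, gives a 1.3-fold lower number from compound 1 to compound 4 (0.12 log units; within the scatter), so that swap also cannot be told apart. The value for compound 3 is only a limit: the limit of > 800 mg/kg in this assay, at which 1 of the 4 values shown sits.

As far as these compounds go, whether an amine or a fluoro at this position would behave like chloro or like methoxy stays open. From the compounds shown here alone, how far compound 3 lies past its limit also stays open.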